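Aryloxy change from compound 3 to compound 4

The source may report more compounds than this note shows. Statements on the series, on what has been measured and on what is new or still open speak of the compounds shown alone.

Compound 3 `CC(Nc1ccccc1Oc1cccc(F)c1)=C1C(=O)CC(c2ccccc2)CC1=O` gives 330 nM in a functional assay on L1210 cells (Mus musculus) for antiproliferative activity, read by cell counting, with a stated time of 96 h (on this read-out lower numbers stand for stronger inhibition and higher numbers for weaker inhibition), the highest number among the three measured compounds. Compound 1 `COc1ccc(Oc2ccccc2NC(C)=C2C(=O)CC(c3ccccc3)CC2=O)cc1` gives 140 nM and compound 2 `COc1cc(Oc2ccccc2NC(C)=C2C(=O)CC(c3ccccc3)CC2=O)ccc1N` gives 26 nM. The steps of a 2.4-fold higher number from compound 1 to compound 3 (0.37 log units; beyond the scatter) and a 13-fold higher number from compound 2 to compound 3 (1.10 log units; beyond the scatter) both run toward the 3-fluorophenyl compound, which is the weaker partner in each comparison against a 4-methoxyphenyl or 4-amino-3-methoxyphenyl on the same oxygen. Compound 4 `CC(Nc1ccccc1Oc1ccc(C(C)O)cc1)=C1C(=O)CC(c2ccccc2)CC1=O` carries the change (4-(1-hydroxyethyl)phenyl in place of 3-fluorophenyl on an oxygen on an aromatic ring). Both bearing steps point the same way, so a lower number than compound 3 is expected, modest to moderate in size, and the expected step is a 3.7-fold lower number from compound 3 to compound 4 (0.56 log units; beyond the scatter). Compound 4 is estimated at 90 nM, with a range from 30 nM to 270 nM.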

Compound 4, half-maximal inhibitory concentration: 58 nM
Estimate against measurement, compound 4: 1.6-fold (0.19 log units) above, and the stated range covers the measured number.
By their numbers in this assay, from the lowest: compound 2; then compound 4; then compound 1; then compound 3.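

In this assay the 4-(1-hydroxyethyl)phenyl group on this oxygen gives a 5.7-fold lower number from compound 3 to compound 4 (0.76 log units; beyond the scatter) and a 2.4-fold lower number from compound 1 to compound 4 (0.38 log units; beyond the scatter), so 1-hydroxyethyl in place of methoxy on an aromatic carbon lowers the number. Still, a 2.2-fold higher number from compound 2 to compound 4 (0.35 log units; beyond the scatter) leaves the 4-amino-3-methoxyphenyl compound with the lowest number of the four. No evidence on hand bears on these steps. Whether the hydroxyl itself matters remains open, since a plain ethyl or an acetyl in the same place is not among the compounds shown. Also open, on these data alone, is how a carboxylic acid or a longer chain would behave there.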